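Exchanging the Terminal Group on the Alkyne Side Chain

The source may report more compounds than this note shows. Statements on the series, on what has been measured and on what is new or still open speak of the compounds shown alone.

For the measured compounds named here, compound 2 `COC(=O)CC/C(C)=C/Cc1c(OC)c(C)c2c(c1OCC#CCN1CCCc3ccccc31)C(=O)OC2` is one of two compounds measured so far in a functional assay on A549 cells (Homo sapiens) for inhibition, read by sulforhodamine B assay; a higher number here means a weaker inhibitor, a lower number a stronger inhibitor. In this assay, going by the values given here, compound 2 gives 18000 nM, the only plain number recorded. Compound 1 `COC(=O)CC/C(C)=C/Cc1c(OC)c(C)c2c(c1OCC#CCN1CCN(c3ccc(C)cc3)CC1)C(=O)OC2` was also tested. In this assay compound 1 reaches a limit, > 50000 nM, which marks the edge of what the assay reports (the limit of > 50000 nM in this assay, at which 1 of the 2 values shown sits). Among the compounds with values here, the two compounds differ in more than one place, so no single step is defined between them; what they show is that compound 1 sits at the limit while compound 2 gives a weak but measurable value.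

Compound 3 `CCCCNc1ccc(CC#CCOc2c(C/C=C(\C)CCC(=O)OC)c(OC)c(C)c3c2C(=O)OC3)cc1` has not yet been measured. It differs from compound 2 by 4-(butylamino)phenyl in place of 1,2,3,4-tetrahydroquinolin-1-yl on a saturated chain carbon bound to a triple-bonded carbon. Within the data shown here, no measured pair shares this change, so the size of the step cannot be read from the data. Because compound 2 in this assay gives 18000 nM, compound 3 is expected to stay close to it, with a step of a 1.1-fold higher number from compound 2 to compound 3 (0.05 log units; within the scatter) not exceeding the usual scatter. Compound 3 is therefore estimated at 20000 nM, with a range from 6000 nM to 60000 nM.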

Compound 3, half-maximal inhibitory concentration: 6970 nM
Beside the measured number, compound 3's estimate is 2.9-fold (0.46 log units) above it; low and high end bracket the measured number.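

For the compounds shown here, this is the only step in the set that can be read: in this assay, 4-(butylamino)phenyl in place of 1,2,3,4-tetrahydroquinolin-1-yl on a saturated chain carbon bound to a triple-bonded carbon gives a 2.6-fold lower number from compound 2 to compound 3 (0.41 log units; beyond the scatter). It shows that the terminal group at this place can move the read-out towards a stronger inhibitor, which the two earlier compounds, differing in more than one place, could not show as a defined step. The change removes the six-membered non-aromatic ring and adds a hydrogen-bond donor, and this single step cannot say which of the two differences matters.

Compound 1 remains a limit and not a number, so how it relates to the other compounds stays unread: the limit of > 50000 nM in this assay, at which 1 of the 3 values shown sits.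
Also open, going by these compounds, is what the butylamino chain itself contributes, which a shorter ethylamino chain, a dimethylamino group or a carboxylic acid in its place on the phenyl ring would help to separate from the loss of the non-aromatic ring.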